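A few compounds are considered here, and "the series" means these few. Any claim that something is new, unique, unknown or untested is made for them only; others in the source may bear on it.

Working notes on the series. Compound 1 `C=CCn1c(=O)/c(=C\c2cccc(F)c2)[nH]c(=O)/c1=C\c1ccccc1OC` is tested in a functional assay on HeLa cells (Homo sapiens) for cytotoxicity, read by CCK-8 assay, with a stated time of 72 h (on this read-out lower numbers stand for stronger inhibition and higher numbers for weaker inhibition), where it gives 9100 nM. Two other members carry results in this assay: compound 2 `C=CCn1c(=O)/c(=C\c2cc(OC)c(OC)c(OC)c2)[nH]c(=O)/c1=C\c1cccc(Br)c1` gives "not active" (no number reported) in this assay, and compound 3 `COc1ccccc1/C=c1/[nH]c(=O)/c(=C\c2nc[nH]c2C(C)(C)C)[nH]c1=O` gives 80 nM in this assay. Of the two numbers shown, compound 1 holds the higher one. Compound 4 `C=CCn1c(=O)/c(=C\c2ccc(Cl)c(Cl)c2)[nH]c(=O)/c1=C\c1ccccc1OC` is not yet measured; it differs from compound 1 by 3,4-dichlorophenyl in place of 3-fluorophenyl on a double-bonded chain carbon bound to an aromatic carbon. Going by the values given here, nothing among the measured compounds isolates this change, so no direction can be read from the data. The step from compound 1 to compound 4 is expected to be small, a 1.3-fold lower number from compound 1 to compound 4 (0.11 log units; within the scatter), and not clearly beyond the scatter. Compound 4 is thus estimated at 7000 nM in this assay, within a range of 2500 nM to 25000 nM.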

Compound 4, half-maximal inhibitory concentration: "not active" (no number reported)
Compound 4 has no reported number here, and the estimate cannot be compared.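

Going by these compounds alone, compound 4 gives no number in this assay, so no step from compound 1 to compound 4 can be read. The compounds shown leave open how far 3,4-dichlorophenyl in place of 3-fluorophenyl shifts the number. No data shown bear on this result.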